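Moving the trifluoromethyl group on a urea's phenyl ring

The compounds below may be only part of what the source reports. "The series", "measured", "known", "first", "only" and "open" are said of these compounds alone.

compound 1 `COc1ccc(Cn2ncc3c2NC(=O)CC(c2cccc(NC(=O)Nc4ccc(Cl)cc4)c2)=N3)cc1`: 640 nM
compound 2 `COc1ccc(Cn2ncc3c2NC(=O)CC(c2cccc(NC(=O)Nc4cccc(C(F)(F)F)c4)c2)=N3)cc1`: 250 nM

In a functional assay on A375P cells (Homo sapiens) for inhibition, read by MTT assay, with a stated time of 24 h (a higher number here means a weaker inhibitor of growth, a lower number a stronger inhibitor of growth), compound 2 has the lower of the two numbers, so it is the stronger growth inhibitor of this pair. The next compound to be tested is compound 3 `COc1ccc(Cn2ncc3c2NC(=O)CC(c2cccc(NC(=O)Nc4ccc(C(F)(F)F)cc4)c2)=N3)cc1`, which has the same atoms as compound 2, joined differently: 4-(trifluoromethyl)phenyl in place of 3-(trifluoromethyl)phenyl on an amide-type nitrogen. In short, 4-(trifluoromethyl)phenyl takes the place of 3-(trifluoromethyl)phenyl on an amide-type nitrogen.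

Among the measured compounds shown here, only one measured step bears on this change: a 2.6-fold lower number from compound 1 to compound 2 (0.41 log units; beyond the scatter). That step is modest, and it swapped 4-chlorophenyl for 3-(trifluoromethyl)phenyl, so the kind of group and its place in the name changed together. The two effects cannot be separated from these data. Compound 3 keeps the trifluoromethyl group of compound 2 but shares the 4- in its group's name with compound 1. A small drift towards a higher number is therefore expected, though probably no clear change beyond the scatter. The expected change is a 1.6-fold higher number from compound 2 to compound 3 (0.20 log units; within the scatter). For compound 3, the estimated value is 400 nM, with an expected range from 150 nM to 1000 nM.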

Compound 3, concentration for 50% growth inhibition: 770 nM
Compound 3: middle estimate off by 1.9-fold (0.28 log units), on the low side, and the stated range covers the measured number.
By their numbers in this assay, from the lowest: compound 2; then compounds 1 and 3 (each within the scatter of the next).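

Moving the trifluoromethyl group while every atom stays the same gives a 3.1-fold higher number from compound 2 to compound 3 (0.49 log units; beyond the scatter) in this assay, so the place of the group on the ring matters on its own, something the earlier step could not show because it changed the group and its place together. With the 4- name kept, exchanging the group itself gives a 1.2-fold higher number from compound 1 to compound 3 (0.08 log units; within the scatter), so chloro and trifluoromethyl cannot be told apart in that setting. Among these three compounds, then, the lower number of compound 2 goes with 3-(trifluoromethyl)phenyl specifically, and not with the trifluoromethyl group wherever it sits; still, nothing measured on these compounds says why one arrangement gives a lower number than the other.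

This dependence on place rests on a single group compared in only two arrangements, so it cannot yet be called a general rule for this ring. From the compounds shown here alone, whether a phenyl ring carrying a methoxy group, a nitrile or a bromine instead would show the same dependence, or whether chloro itself would respond to a move as trifluoromethyl does, stays open.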